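Removing a Chloro Group from Two Related Melanoma Inhibitors

A few compounds are considered here, and "the series" means these few. Any claim that something is new, unique, unknown or untested is made for them only; others in the source may bear on it.

Three compounds were measured in a functional assay on B16-F10 cells (Mus musculus) for inhibition, read by MTT assay, with a stated time of 72 h; on this read-out lower numbers stand for stronger inhibition and higher numbers for weaker inhibition:
compound 1 `CC(C)c1ccc(-c2nc(SCc3cn(CC(=O)NC(=O)Nc4ccccn4)nn3)nc(Nc3ccccc3Cl)c2C#N)cc1`, for which compound 1 gives 6790 nM;
compound 2 `CC(C)c1ccc(-c2nc(SCc3cn(CC(=O)NC(=O)Nc4ccccn4)nn3)nc(Nc3ccccc3)c2C#N)cc1`, for which compound 2 gives 14300 nM;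
compound 3 `Cc1ccc(Nc2nc(SCc3cn(CC(=O)NC(=O)Nc4ccccn4)nn3)nc(-c3ccc(Cl)cc3)c2C#N)cc1`, for which compound 3 gives 1320 nM.

Compound 3 has the lowest number of the three. How its core differs from the core of compound 1 is not broken down here. Between compounds 1 and 2 the change hydrogen in place of chloro on an aromatic carbon gave a 2.1-fold higher number from compound 1 to compound 2 (0.32 log units; beyond the scatter). Compound 4 `Cc1ccc(Nc2nc(SCc3cn(CC(=O)NC(=O)Nc4ccccn4)nn3)nc(-c3ccccc3)c2C#N)cc1` has not been measured; it arises from compound 3 through (hydrogen in place of chloro on an aromatic carbon). The place is not the same: in compound 1 the chloro sits ortho to a large group, in compound 3 para to a large group, so this is the same kind of change, not the same change. In this assay the step from compound 3 to compound 4 is expected to be a 2.1-fold higher number from compound 3 to compound 4 (0.33 log units; beyond the scatter), a modest weakening. That expectation rests on a 2.1-fold higher number from compound 1 to compound 2 (0.32 log units; beyond the scatter). Compound 4 is estimated at 2800 nM, between 1300 nM and 6000 nM.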

Compound 4, half-maximal inhibitory concentration: 3300 nM
For compound 4 the middle estimate is 1.2-fold (0.07 log units) below the measured one, within the range that was stated.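

In this assay the exchange of chloro for hydrogen on an aromatic carbon gave a 2.5-fold higher number from compound 3 to compound 4 (0.40 log units; beyond the scatter) as a modest weakening. The change thus carried over from one core to the other at a similar size, even though the chloro stands at a different place in each pair: the same change on two cores in this assay, a 2.1-fold higher number (0.32 log units; beyond the scatter) from compound 1 to compound 2 and a 2.5-fold higher number (0.40 log units; beyond the scatter) from compound 3 to compound 4, 1.2-fold (0.07 log units) apart, within the scatter of two such steps. This rests on two pairs only, and it shows neither why the number rises nor that the change would behave alike on any further core or at any other place.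

The compounds shown carry only chloro or hydrogen at these places, so it remains open how a fluoro group, a methoxy group or an amine would read there. Going by these compounds, whether the step holds on other cells also remains open.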